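Swapping an aminooxetane for a piperazine on a quinoline amine

A few compounds are considered here, and "the series" means these few. Any claim that something is new, unique, unknown or untested is made for them only; others in the source may bear on it.

Measured so far, in an ADME assay on HEp-2 cells (Homo sapiens) for cytotoxicity, read by CCK-8 assay, with a stated time of 5 days; a higher number here means that more compound is tolerated, a lower number that less compound is tolerated:
- compound 1 `Cc1ccc2nc(N3CCCc4ccc(F)cc4C3)cc(NCC3(N)COC3)c2c1` gives > 100000 nM, which is a limit of the assay rather than a number.
- compound 2 `N=C(N)NCCNc1cc(N2CCc3ccccc3C2)nc2ccccc12` gives > 100000 nM, likewise a limit.
- compound 3 `NCC(O)CNc1cc(N2CCCc3ccccc3C2)nc2ccccc12` gives 21000 nM.

Compound 1 therefore has no exact figure in this assay; it sits at the limit of > 100000 nM in this assay, at which 2 of the 3 values shown sit, so its cytotoxicity is simply below what the test can resolve. Compound 3 is the only one of the three with a measured number, and it is lower than the limit at which the other two rest.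

Compound 4 `Cc1ccc2nc(N3CCCc4ccc(F)cc4C3)cc(NCCN3CCNCC3)c2c1` is the next step from compound 1. The change is (piperazin-1-yl)methyl in place of 3-aminooxetan-3-yl on a saturated chain carbon bound to a nitrogen on an aromatic ring. In words, the 2-(piperazin-1-yl)ethyl chain takes the place of the (3-aminooxetan-3-yl)methyl chain on the nitrogen attached to the shared core.

Among the measured compounds shown here, no measured pair here isolates this kind of change, so the expected size of the step from compound 1 to compound 4 in this assay is none beyond the usual scatter, and the estimate an at least 1.2-fold lower number from compound 1 to compound 4 (0.09 log units; that floor lies within the scatter) reflects that; a result that again reads only as a limit is the likeliest outcome. The estimated value for compound 4 is 80000 nM, within a range of 20000 nM to 250000 nM.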

Compound 4, half-maximal cytotoxic concentration: 40000 nM
Compound 4: the middle estimate sits 2.0-fold (0.30 log units) above what was measured; measured number inside the range.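

In this assay, putting the 2-(piperazin-1-yl)ethyl chain in place of the (3-aminooxetan-3-yl)methyl chain on the nitrogen attached to the shared core gives an at least 2.5-fold lower number from compound 1 to compound 4 (0.39 log units; beyond the scatter). This is the first pair shown that differs in one place, and it shows that the group at this position can change how much compound the cells tolerate, with compound 4 giving a measured 40000 nM rather than a limit. The value of compound 1 is a limit and not a number, so the true size of the step stays unknown and only its smallest possible size can be read: the limit of > 100000 nM in this assay, at which 2 of the 4 values shown sit.

The compounds shown leave open whether the change follows from the piperazine ring itself or from the move to the ethyl chain, as the two differ together in this single pair. A morpholine ring or a simple dimethylamino group on the same ethyl chain, or a piperazine ring on a chain of the shorter length, would help to separate these two readings of the result.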